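This account rests on a few compounds, and the source may have more. Where it says the series, first, only, none or still open, it means among the compounds named here.

Of the compounds shown here, three have been tested in a functional assay on SW-620 cells (Homo sapiens) for inhibition; a lower number here means a stronger inhibitor, a higher number a weaker inhibitor. Compound 1 `CCC(C)C1NC(=O)N(C2CCCC2)C1=O` reaches only the assay limit, reported as > 100000 nM. Compound 2 `CCC(C)C(NC(=O)n1nnc2ccccc21)C(=O)NC1CCCCC1` likewise gives only a limit, > 100000 nM. Both of these sit at the limit of > 100000 nM in this assay, at which 2 of the 3 values shown sit. Among the measured compounds shown here, compound 3 `O=C1NC(c2ccccc2)C(=O)N1Cc1ccccc1` is the one with an actual number, 96800 nM. The unmeasured compound 4 `CCC(C)C(NC(=O)n1nnc2ccccc21)C(=O)NC1CCCC1` differs from compound 2 by cyclopentyl in place of cyclohexyl on an amide-type nitrogen. For the measured compounds named here, no measured pair shows this change, and because compound 2 itself stands at a limit, no step size can be read off. Compound 4 is therefore expected to stay at or near the limit, with an expected change a step that the limit leaves unreadable from compound 2 to compound 4 that means nothing beyond the scatter. The estimate for compound 4 is 150000 nM, within 50000 nM to 500000 nM.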

Compound 4, half-maximal inhibitory concentration: > 100000 nM
Compound 4 gave a limit, no number; the forecaster's own chance of this, stated with the estimate: 85%; the middle value does not contradict the limit.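

No step size can be read from compound 2 to compound 4, because both give only a limit: the limit of > 100000 nM in this assay, at which 3 of the 4 values shown sit. The compounds shown leave open how cyclopentyl and cyclohexyl on this amide-type nitrogen compare in actual potency.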